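Aryl change on the ring nitrogen: compound 1 to compound 4

A few compounds are considered here, and "the series" means these few. Any claim that something is new, unique, unknown or untested is made for them only; others in the source may bear on it.

Measured so far:
- compound 1 `COc1cc2c(Oc3ccc(NC(=O)c4nn(-c5ccccc5OC(F)(F)F)c(=O)cc4C)cc3F)ccnc2cc1OCCCN1CCCC1` gives 60 nM in a functional assay on MKN-45 cells (Homo sapiens) for inhibition, read by MTT assay, with a stated time of 72 h; a higher number here means a weaker inhibitor, a lower number a stronger inhibitor
- compound 2 `COc1cc2c(Oc3ccc(NC(=O)c4nn(-c5ccccc5OC(F)(F)F)c(=O)cc4C)cc3F)ccnc2cc1OCCCN1CCCCC1` gives 40 nM in this assay
- compound 3 `COc1cc2c(Oc3ccc(NC(=O)c4nn(-c5ccccc5OC(F)(F)F)c(=O)cc4C)cc3F)ccnc2cc1OCCCN1CCN(C)CC1` gives 100 nM in this assay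

Compound 1 stands second highest of the three numbers; its step to compound 2 is a 1.5-fold lower number from compound 1 to compound 2 (0.18 log units; within the scatter) and its step to compound 3 is a 1.7-fold higher number from compound 1 to compound 3 (0.22 log units; within the scatter), both within the scatter. For the measured compounds named here, the only step beyond the scatter is a 2.5-fold higher number from compound 2 to compound 3 (0.40 log units; beyond the scatter), modest in size.

Compound 4 `COc1cc2c(Oc3ccc(NC(=O)c4nn(-c5ccc(F)c(F)c5)c(=O)cc4C)cc3F)ccnc2cc1OCCCN1CCCC1` differs from compound 1 by 3,4-difluorophenyl in place of 2-(trifluoromethoxy)phenyl on an aromatic nitrogen. Every measured step in the series concerns the amine on the saturated chain, three bonds along the chain from an oxygen on an aromatic ring; none touches the aryl group on the ring nitrogen. Going by the values given here, no measured step therefore bears on this change, and the measured steps themselves are all small. Absent any evidence, compound 4 is expected to sit near compound 1, as a step of no change at the digits printed from compound 1 to compound 4 (within the scatter) in this assay, with a wide range to reflect that the change is untested. Compound 4 is estimated at 60 nM, between 20 nM and 200 nM.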

Compound 4, half-maximal inhibitory concentration: 80 nM
Compound 4: middle estimate off by 1.3-fold (0.12 log units), on the low side; the measured number falls inside the stated range.
By their numbers in this assay, from the lowest: compounds 2, 1, 4 and 3 (each within the scatter of the next, the first and the last beyond it).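

In this assay the aryl group on the aromatic nitrogen now has its first measured step, a 1.3-fold higher number from compound 1 to compound 4 (0.12 log units; within the scatter), which stays within the scatter. This exchange of 2-(trifluoromethoxy)phenyl for 3,4-difluorophenyl takes the group from 11 heavy atoms to 8 and from 1 hydrogen-bond acceptor to 0, so on the pyrrolidin-1-yl compounds this position accepts a clearly different substitution pattern without a change that can be told from the scatter. Nothing at hand speaks to the reason for this result.

As far as these compounds go, whether the same holds with piperidin-1-yl or 4-methylpiperazin-1-yl at the end of the chain stays open, since the aryl change is read only between compound 1 and compound 4. Also open, from the compounds shown here alone, is how an unsubstituted phenyl or a 4-methoxyphenyl group on the ring nitrogen would read in this assay.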